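This account rests on a few compounds, and the source may have more. Where it says the series, first, only, none or still open, it means among the compounds named here.

Compound 1 `CN(C)C(=O)/C=C1\CCc2c(F)cc(F)cc21`: 100 mg/kg
Compound 2 `O=C(/C=C1\CCc2cc(F)cc(F)c21)NC1CC1`: 81 mg/kg

Both values come from a functional assay on the whole organism with Mus musculus as the target, in the rotarod test; a lower number here means that less compound is needed, a higher number that more compound is needed for the effect. Compound 2, at 81 mg/kg, lies within the usual scatter of compound 1, at 100 mg/kg, so the two numbers cannot be told apart, and they are all that is known so far in this series.

The next compound to be measured in this assay is compound 3 `NC(=O)/C=C1\CCc2cc(F)cc(F)c21`. It is derived from compound 2 by putting hydrogen in place of cyclopropyl on an amide-type nitrogen. Among the compounds with values here, no measured pair shows this change on its own, so the data offer no direct guide to its effect, and no direction can be argued with confidence. The only support is the closeness of compound 1 at 100 mg/kg and compound 2 at 81 mg/kg. On that thin basis, no change beyond the scatter is expected, and the expected step is a 1.2-fold higher number from compound 2 to compound 3 (0.09 log units; within the scatter). For compound 3 the estimated value is 100 mg/kg, with an expected range from 45 mg/kg to 220 mg/kg.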

Compound 3, dose for half-maximal effect: 81 mg/kg
The estimate for compound 3 lay 1.2-fold (0.09 log units) above the measured number; the measured number falls inside the stated range.
By their numbers in this assay, from the lowest: compounds 2, 3 and 1 (each within the scatter of the next).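

In this assay, within the data shown here, the step of no change at the digits printed from compound 2 to compound 3 (within the scatter) gives the first direct reading at this amide-type nitrogen, with hydrogen in place of cyclopropyl and everything else in the structure held the same. Compound 1 differs from compound 2 in more than one place, so the earlier pair could not isolate this nitrogen, whereas the new pair shows that, in this assay and on this core, the two groups cannot be told apart: neither the cyclopropyl ring nor its three carbon atoms leaves a difference beyond the scatter. No measurement available here bears on the reason for this result.

As far as these compounds go, with only hydrogen and cyclopropyl compared directly at this nitrogen, the result cannot be extended to other groups, and it remains open whether a longer chain such as n-butyl, a benzyl group, or a chain ending in an amine or a carboxylic acid would give a number beyond the scatter. From the compounds shown here alone, it is also open whether hydrogen and cyclopropyl would stay indistinguishable on a core carrying its fluorines as compound 1 does.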